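The source may report more compounds than this note shows. Statements on the series, on what has been measured and on what is new or still open speak of the compounds shown alone.

In a functional assay on Bel-7402 cells (Homo sapiens) for antiproliferative activity, read by MTT assay, with a stated time of 72 h (a lower number here means a stronger inhibitor, a higher number a weaker inhibitor), two compounds sharing one core have been measured so far. Compound 1 (`C=C1C(=O)O[C@H]2[C@H]1CC/C(COC(=O)CCC(=O)NCCCCCCNC(=O)Cn1cc(F)c(=O)n(Cc3ccccc3)c1=O)=C\CC[C@@]1(C)O[C@@H]21`) gives 18300 nM, and compound 2 (`C=C1C(=O)O[C@H]2[C@H]1CC/C(COC(=O)Cn1cc(F)c(=O)n(Cc3ccc([N+](=O)[O-])cc3)c1=O)=C\CC[C@@]1(C)O[C@@H]21`) gives 4070 nM. Compound 2 thus holds the lower of the two numbers, and the gap between them lies beyond the usual scatter. Compound 3 (`C=C1C(=O)O[C@H]2[C@H]1CC/C(COC(=O)Cn1cc(F)c(=O)n(CCC)c1=O)=C\CC[C@@]1(C)O[C@@H]21`) keeps the rest of compound 2 and changes one group: ethyl in place of 4-nitrophenyl on a saturated chain carbon bound to an aromatic nitrogen. Ethyl takes the place of 4-nitrophenyl on a saturated chain carbon bound to an aromatic nitrogen, which turns 4-nitrobenzyl into propyl. Among the compounds with values here, no measured pair shows this change, so its size remains uncertain. A modest move toward a higher number is expected, near the edge of the scatter, and the estimated step is a 1.8-fold higher number from compound 2 to compound 3 (0.27 log units; within the scatter). For compound 3 the estimate is 7500 nM, with an expected range of 2800 nM to 20000 nM.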

Compound 3, half-maximal inhibitory concentration: 8580 nM
The estimate for compound 3 lay 1.1-fold (0.06 log units) below the measured number, within the range that was stated.
By their numbers in this assay, from the lowest: compound 2; then compound 3; then compound 1.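

Within the data shown here, this pair is the first to differ in one place only, so it gives the first direct reading on the saturated chain carbon bound to an aromatic nitrogen: in this assay, ethyl in place of 4-nitrophenyl gives a 2.1-fold higher number from compound 2 to compound 3 (0.32 log units; beyond the scatter). The change removes the only aromatic ring of carbon from this substituent, and the number moves beyond the scatter, though only by a modest step. Nothing given here accounts for the step.

The pair leaves open whether the step follows the loss of the ring or the loss of its nitro group. Going by these compounds, how the number would respond to a 4-aminobenzyl group, or to a longer chain such as hexyl in place of propyl, also remains open on this core.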